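A Methoxy Group Added to an Inactive Phenylpiperazine

This account rests on a few compounds, and the source may have more. Where it says the series, first, only, none or still open, it means among the compounds named here.

Compound 2 `S=c1oc(-c2ccc3c(c2)OCCO3)nn1CN1CCN(c2ccccc2)CC1` was tested in a functional assay on HepG2 cells (Homo sapiens) for antiproliferative activity, read by MTT assay, with a stated time of 48 h; a higher number here means a weaker inhibitor, a lower number a stronger inhibitor. Compound 2 gives > 50000 nM, which is a limit of the assay rather than a number. Its chloro-bearing partner compound 1 `S=c1oc(-c2ccc3c(c2)OCCO3)nn1CN1CCN(c2ccc(Cl)cc2)CC1` gives > 50000 nM, also a limit. The step that the two limits leave unreadable from compound 1 to compound 2 therefore cannot be read, as shown by the limit of > 50000 nM in this assay, at which 2 of the 2 values shown sit. Compound 3 `COc1ccccc1N1CCN(Cn2nc(-c3ccc4c(c3)OCCO4)oc2=S)CC1` differs from compound 2 by methoxy in place of hydrogen on an aromatic carbon, on an aromatic carbon ortho to a large group. Among the compounds with values here, no measured step bears on this change. Compound 3 is expected to stay near the limit, so the step that the limit leaves unreadable from compound 2 to compound 3 is estimated as none beyond the scatter. Compound 3 is therefore estimated at 60000 nM, within 15000 nM to 200000 nM.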

Compound 3, half-maximal inhibitory concentration: 15500 nM
Compound 3: middle estimate off by 3.9-fold (0.59 log units), on the high side, within the range that was stated.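

Methoxy in place of hydrogen on an aromatic carbon, ortho to a large group, brings the series off its limit in this assay, with an at least 3.2-fold lower number from compound 2 to compound 3 (0.50 log units; beyond the scatter). Against the chloro-bearing partner, 2-methoxyphenyl in place of 4-chlorophenyl gives an at least 3.2-fold lower number from compound 1 to compound 3 (0.50 log units; beyond the scatter). Both steps are minimum sizes, as compound 1 and compound 2 stop at a limit of the assay: the limit of > 50000 nM in this assay, at which 2 of the 3 values shown sit.

From the compounds shown here alone, it remains open whether methoxy elsewhere on the same ring would give a similar step. Also open, going by these compounds, is whether an ethoxy or a hydroxyl group in this place would match it.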